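Iodo for Fluoro: an Expected Step in Rats

This account rests on a few compounds, and the source may have more. Where it says the series, first, only, none or still open, it means among the compounds named here.

Of the compounds shown here, three have so far been tested in a functional assay on the whole organism for inhibition, with Rattus norvegicus as the target (a higher number here means that more compound is needed for the effect, a lower number that less compound is needed), and each of them gives only a limit of the assay rather than a number. Compound 1 `CC1CC/C(=N\Nc2cccc(C(=O)O)c2)c2nccc(=O)n21` reaches only > 100 umol/kg in this assay, a limit. Compound 2 `CC1CC/C(=N\Nc2ccccc2)c2ncc(C#N)c(=O)n21` gives > 1000 umol/kg in this assay, again a limit. Compound 3 `CC1CC/C(=N\Nc2ccccc2F)c2ncc(C(=O)O)c(=O)n21` likewise gives > 1000 umol/kg in this assay, a limit and not a measured number. So the limit of > 100 umol/kg in this assay, at which 1 of the 3 values shown sits, and the limit of > 1000 umol/kg in this assay, at which 2 of the 3 values shown sit, together hold everything known, and no measured step between any pair of compounds exists.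

Compound 4 `CC1CC/C(=N\Nc2ccccc2I)c2ncc(C(=O)O)c(=O)n21` differs from compound 3 in one place: iodo in place of fluoro on an aromatic carbon. The iodo enters on an aromatic carbon of a six-membered aromatic ring of carbon only, ortho to a large group, where the fluoro leaves. Because all three values rest at limits, no direction can be read from them. The step of a number no higher from compound 3 to compound 4 (the limit leaves the size open) is expected to be none beyond the scatter. Compound 4 is therefore estimated at 1000 umol/kg in this assay, within a range from 300 umol/kg to 3000 umol/kg, and most likely only a limit will again be reported.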

Compound 4, dose for 50% inhibition: > 1000 umol/kg
Compound 4: only a limit was reported; the forecaster's own chance of this, stated with the estimate: 80%; the middle value sits exactly at the limit.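

For the compounds shown here, compound 3 and compound 4 both rest at limits of this assay, so no step between them can be read. The compounds shown leave open whether iodo in place of fluoro changes the dose needed, and what dose any of these compounds would require.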